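The compounds below may be only part of what the source reports. "The series", "measured", "known", "first", "only" and "open" are said of these compounds alone.

Compound 1 `CC(=O)/C=C1\C[C@H]2SC(C)(C)[C@H](C(=O)OC(c3ccccc3)c3ccccc3)N2C1=O`: in a functional assay on A-375 cells (Homo sapiens) for cytotoxicity, read by MTT assay, with a stated time of 48 h (a lower number here means a stronger inhibitor, a higher number a weaker inhibitor), compound 1 gives > 100000 nM, which is a limit of the assay and not a number.
Compound 2 `CC1(C)S[C@@H]2C/C(=C\C(=O)c3ccccc3)C(=O)N2[C@H]1C(=O)OC(c1ccccc1)c1ccccc1`: in this assay compound 2 gives > 100000 nM, likewise a limit.
Compound 3 `CC(=O)/C=C1/C(=O)N2[C@@H]1SC(C)(C)[C@@H]2C(=O)OC(c1ccccc1)c1ccccc1`: in this assay compound 3 gives 63000 nM.

Going by the values given here, compound 3 therefore carries the only number among the three values shown; the other two sit at the limit of > 100000 nM in this assay, at which 2 of the 3 values shown sit, and cannot be placed against it. Compound 4 `CC1(C)S[C@@H]2/C(=C\C(=O)c3cc(F)cc(F)c3)C(=O)N2[C@H]1C(=O)OC(c1ccccc1)c1ccccc1` differs from compound 3 by 3,5-difluorophenyl in place of methyl on a carbonyl carbon. Among the compounds with values here, the only measured step of a related kind is a step that the two limits leave unreadable from compound 1 to compound 2, and it is unreadable, since both of its compounds rest at the limit of > 100000 nM in this assay, at which 2 of the 3 values shown sit. Within the data shown here, compounds 1 and 2 also share a core that differs from the one shared by compounds 3 and 4, so that step would be a loose guide even if it were readable. Among the measured compounds shown here, no measured step shows whether an aromatic ring on this carbonyl carbon helps or hurts, so nothing can be said about the direction of the change in this assay, and no step beyond the scatter is foreseen from the evidence at hand. On that basis compound 4 is expected to give about 50000 nM in this assay, with a wide range from 8000 nM to 200000 nM, and the expected step of a 1.3-fold lower number from compound 3 to compound 4 (0.10 log units; within the scatter) is held near zero.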

Compound 4, half-maximal inhibitory concentration: 19100 nM
Beside the measured number, compound 4's estimate is 2.6-fold (0.42 log units) above it; the measured number falls inside the stated range.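

In this assay, going by these compounds alone, the change from acetyl to (3,5-difluorophenyl)carbonyl gives the first readable step at this carbonyl carbon, a 3.3-fold lower number from compound 3 to compound 4 (0.52 log units; beyond the scatter), and this step lies beyond the usual scatter, though it is modest. It shows that, on this core, the aromatic ring and its two fluorines can replace the methyl without loss of activity in the cells, and that the number moves toward stronger inhibition. The related step on the other core remains unreadable, so this result cannot be extended to that core, and compound 1 and compound 2 each rest at a limit of the assay, not a number: the limit of > 100000 nM in this assay, at which 2 of the 4 values shown sit.

The compounds shown leave open whether this gain belongs to the aromatic ring itself or to its two fluorines, as plain phenyl appears only on the other core, where no comparison can be read. They also leave open how this assay would respond to a ring carrying an amine or a methoxy group at this carbonyl carbon, or to a free carboxylic acid in place of the diphenylmethyl ester.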